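The source may hold more compounds than are shown below. What is called first, only, known or untested is meant among the compounds shown, and "the series" means these compounds.

Of the compounds shown here, three of one series have been tested in a functional assay on NCI-H1650 cells (Homo sapiens) for cytotoxicity, read by MTT assay, with a stated time of 48 h; on this read-out higher numbers stand for weaker inhibition and lower numbers for stronger inhibition. Compound 1 `CN(C)CCCNc1ccnc2cc(OCc3ccc(F)cc3)ccc12` gives 940 nM. Compound 2 `Fc1ccc(COc2ccc3c(Cl)ccnc3c2)cc1` differs from compound 1 by chloro in place of (3-(dimethylamino)propyl)amino on an aromatic carbon; in this assay compound 2 gives 2230 nM, and here a 2.4-fold higher number from compound 1 to compound 2 (0.38 log units; beyond the scatter). Compound 3 `C=CCOc1ccc2c(NCCCN(C)C)ccnc2c1` gives 3120 nM; here a 3.3-fold higher number from compound 1 to compound 3 (0.52 log units; beyond the scatter). Compound 2 and compound 3 lie within the usual scatter of each other, so no order between them is claimed.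

Compound 4 `C=CCOc1ccc2c(Cl)ccnc2c1` has not yet been measured in this assay. It differs from compound 3 by chloro in place of (3-(dimethylamino)propyl)amino on an aromatic carbon. This is the same change that turns compound 1 into compound 2, made at the same place, but on a different core: the core of compound 3 differs from that of compound 1 by vinyl in place of 4-fluorophenyl on a saturated chain carbon bound to an oxygen on an aromatic ring. For the measured compounds named here, only one earlier example of this change exists, so the expectation rests on it alone. Because a 2.4-fold higher number from compound 1 to compound 2 (0.38 log units; beyond the scatter), the expected step is a 2.4-fold higher number from compound 3 to compound 4 (0.38 log units; beyond the scatter), a similar weakening. Compound 4 is therefore expected to give about 7500 nM, with a likely range from 3500 nM to 16000 nM.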

Compound 4, half-maximal inhibitory concentration: 2280 nM
The estimate for compound 4 lay 3.3-fold (0.52 log units) above the measured number; measured number below the stated range.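

In this assay, chloro in place of (3-(dimethylamino)propyl)amino gives a 1.4-fold lower number from compound 3 to compound 4 (0.14 log units; within the scatter), so on the core of compound 3 this change separates the two compounds by no more than ordinary repeat variation. The change therefore did not behave the same way on the two cores, since the step seen on the core of compound 1 did not carry over: the same change on two cores in this assay, a 2.4-fold higher number (0.38 log units; beyond the scatter) from compound 1 to compound 2 and a 1.4-fold lower number (0.14 log units; within the scatter) from compound 3 to compound 4, 3.2-fold (0.51 log units) apart, beyond the scatter of two such steps This shows that, in this series, the result of the change depends on the rest of the molecule, so one example on one core is a poor guide to another; it does not show why the two steps differ, and two cores cannot give a rule for any further core.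

The compounds shown leave open how the same change behaves with other groups on the ether side chain, such as a plain phenyl or a longer saturated chain. They also leave open what happens when chloro is compared with a different amine, such as one with a longer chain or a primary amine, rather than (3-(dimethylamino)propyl)amino.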